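Fluoro in place of ethoxy at the assay limit

This account rests on a few compounds, and the source may have more. Where it says the series, first, only, none or still open, it means among the compounds named here.

Values in a functional assay on K562 cells (Homo sapiens) for antiproliferative activity, read by MTT assay, with a stated time of 72 h (on this read-out higher numbers stand for weaker inhibition and lower numbers for stronger inhibition), for the measured compounds follow.
Compound 1 `COc1cc(-n2ncnc2-c2ccc(C)cc2)cc(OC)c1OC` gives > 10000 nM (a limit)
Compound 2 `COc1ccc(-c2ncnn2-c2cc(OC)c(OC)c(OC)c2)cc1` gives 950 nM (a number)
Compound 3 `CCOc1cccc(-c2ncnn2-c2cc(OC)c(OC)c(OC)c2)c1` gives > 10000 nM (a limit)

Compound 3 stands at > 10000 nM, which is a limit of this assay and not a number. Compound 4 `COc1cc(-n2ncnc2-c2cccc(F)c2)cc(OC)c1OC` has not yet been measured. It differs from compound 3 by fluoro in place of ethoxy on an aromatic carbon. Within the data shown here, the one measured step is an at least 10-fold lower number from compound 1 to compound 2 (1.02 log units; beyond the scatter). It comes with methoxy in place of methyl on an aromatic carbon, a different exchange from this one, so it sets no size for the present change. More relevant is the limit of > 10000 nM in this assay, at which 2 of the 3 values shown sit. A large step away from compound 3 is therefore not expected, and no direction can be firmly given, although a modest move to a lower number remains possible. The expected result is a number no higher from compound 3 to compound 4 (the limit leaves the size open) in this estimate. Compound 4 is estimated at 10000 nM, with an expected range from 2000 nM to 40000 nM, and it may well report only a limit.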

Compound 4, half-maximal inhibitory concentration: > 10000 nM
Compound 4: a limit, no number; the forecaster's own chance of this, stated with the estimate: 65%; the middle value lies on the limit itself.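

In this assay compound 4 gives > 10000 nM, which is a limit and not a number. Among these compounds, the one readable step is an at least 10-fold higher number from compound 2 to compound 4 (1.02 log units; beyond the scatter), with 3-fluorophenyl in place of 4-methoxyphenyl on an aromatic carbon. The steps from compound 3 and from compound 1 to compound 4 cannot be read, so fluoro in place of ethoxy has no measured size, and compound 2 remains the only compound shown with a number: the limit of > 10000 nM in this assay, at which 3 of the 4 values shown sit.

From the compounds shown here alone, how far compound 1, compound 3 and compound 4 lie beyond the limit stays open, and with it whether fluoro and ethoxy differ at all at this place. Also open, going by these compounds, is whether an amine or a chloro group at this place would give a number in this assay.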